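Piperidine amide in place of indolylmethyl on the oxazolidinone core

The source may hold more compounds than are shown below. What is called first, only, known or untested is meant among the compounds shown, and "the series" means these compounds.

Compound 1 `O=C1OC(c2cccc3ccccc23)CN1C1CCN(Cc2cc3ccccc3[nH]2)CC1` and compound 3 `COc1ccc2nccc(C3CN(C4CCN(Cc5c[nH]c6ccccc56)CC4)C(=O)O3)c2c1` share the core with compound 2 `COc1ccc2nccc(C3CN(C4CCN(Cc5cc6ccccc6n5C)CC4)C(=O)O3)c2c1`. In an in vitro functional assay on RBL cells for antagonist activity at C-C chemokine receptor type 8 (Homo sapiens), read by FLIPR and calcium flux (a lower number here means a stronger inhibitor, a higher number a weaker inhibitor), compound 1 reports only a limit, < 50200 nM. Compound 3 likewise reports only a limit in this assay, < 50200 nM. Going by the values given here, compound 2 is the sole member with a number, giving 3160 nM in this assay, so it stands as the one readable point of the set. Among the compounds with values here, the single one-place step, a step that the limit leaves unreadable from compound 2 to compound 3, cannot be sized since (the limit of < 50200 nM in this assay, at which 2 of the 3 values shown sit).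

Compound 4 `COc1ccc2nccc(C3CN(C4CCN(C(=O)c5ccc(Cl)c(Cl)c5)CC4)C(=O)O3)c2c1` differs from compound 2 as follows: (3,4-dichlorophenyl)carbonyl in place of (1-methyl-1H-indol-2-yl)methyl on an amine nitrogen in a ring. Within the data shown here, no measured step touches this change: the only step recorded, a step that the limit leaves unreadable from compound 2 to compound 3, is unreadable, and no measured compound carries a carbonyl on an amine nitrogen in a ring. The expectation therefore rests on compound 2 at 3160 nM alone and is wide. Compound 4 is estimated at 8000 nM, within a range of 1000 nM to 50000 nM, with a real chance that only a limit is returned. The step this estimate implies is a 2.5-fold higher number from compound 2 to compound 4 (0.40 log units; beyond the scatter), expected as a loss beyond the scatter, though the direction itself is uncertain.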

Compound 4, half-maximal inhibitory concentration: 6310 nM
The estimate for compound 4 lay 1.3-fold (0.10 log units) above the measured number, within the range that was stated.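

On an amine nitrogen in a ring, the indole is not needed for a readable number in this assay: (3,4-dichlorophenyl)carbonyl in place of (1-methyl-1H-indol-2-yl)methyl gives a 2.0-fold higher number from compound 2 to compound 4 (0.30 log units; within the scatter), and compound 4 is the second readable point of the set. An indole on this nitrogen does not ensure a readable number either, as compound 3 carries (1H-indol-3-yl)methyl and reports only a limit. The step from compound 3 to compound 4 and the step from compound 2 to compound 3 cannot be read: the limit of < 50200 nM in this assay, at which 2 of the 4 values shown sit.

Going by these compounds, the change replaces the ring system and the carbonyl link together, and the share of each stays unknown; (3,4-dichlorophenyl)methyl on the same nitrogen would separate them. Also open, on these data alone, is how this nitrogen responds to a sulfonyl link or to a chain ending in a carboxylic acid.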